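Fluoro removal on the fused ring of compound 2

A few compounds are considered here, and "the series" means these few. Any claim that something is new, unique, unknown or untested is made for them only; others in the source may bear on it.

Measured so far:
compound 1, `CCCCNc1nc(NCc2ccco2)c2ccccc2n1`: 4990 nM
compound 2, `Cc1cccc(N2CCN(CCCCNc3nc(NCc4ccco4)c4cc(F)ccc4n3)CC2)c1C`: 3320 nM

Compound 1 carries the bare core with a butylamino chain. In a functional assay on DU-145 cells (Homo sapiens) for cytotoxicity, read by MTT assay, with a stated time of 2 days (a lower number here means a stronger inhibitor, a higher number a weaker inhibitor), compound 1 gives 4990 nM. Compound 2 adds the arylpiperazine-bearing chain and a fluoro on the fused ring; in this assay compound 2 gives 3320 nM, the lower of the two numbers, though the gap to compound 1 lies within the scatter of repeated measurements, so no order between them can be claimed.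

Compound 3, `Cc1cccc(N2CCN(CCCCNc3nc(NCc4ccco4)c4ccccc4n3)CC2)c1C`, has not yet been measured in this assay. It differs from compound 2 in one place: hydrogen in place of fluoro on an aromatic carbon. Going by the values given here, no measured pair shows this change, so its size is unknown from the data in hand. The expectation is a small step, none beyond the scatter, in either direction. The expected step of a 1.1-fold higher number from compound 2 to compound 3 (0.06 log units; within the scatter) is therefore set near zero. For compound 3 the estimate in this assay is 3800 nM, expected to fall between 1500 nM and 9500 nM.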

Compound 3, half-maximal inhibitory concentration: 1070 nM
Compound 3: the middle estimate sits 3.6-fold (0.55 log units) above what was measured, outside the stated range (below it).
By their numbers in this assay, from the lowest: compound 3; then compounds 2 and 1 (each within the scatter of the next).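

In this assay the step of a 3.1-fold lower number from compound 2 to compound 3 (0.49 log units; beyond the scatter) lies beyond the scatter, so this aromatic carbon, meta to a fused ring and para to a fused ring, is not indifferent to what it carries: the hydrogen form gives the lower number. This rests on one pair, so it holds for this chain and this arylpiperazine alone, and no general rule on fluoro follows from it. Nothing at hand bears on why the number moves.

Still open, going by these compounds, is whether a chloro or a methoxy on the same aromatic carbon would read like the fluoro or like the hydrogen. Also open, on these data alone, is whether the same fluoro-to-hydrogen step would hold with a shorter propyl chain in place of the butyl chain.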